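A few compounds are considered here, and "the series" means these few. Any claim that something is new, unique, unknown or untested is made for them only; others in the source may bear on it.

Working notes on the series. In a functional assay on HEK293 cells for agonist activity at G-protein coupled receptor 39 (Mus musculus), read by inositol phosphate accumulation (a higher number here means that more compound is needed for the effect, a lower number that less compound is needed), compound 1 `CNc1nc(NCC(C)(C)C)cc(-c2ccccn2)n1` gives 365 nM and stands second highest of the three numbers recorded. Compound 2 `c1ccc(-c2cc(NCC3CC3)ncn2)nc1` gives 10000 nM in this assay, the highest number of the set, and compound 3 `CNC(=O)c1ccc(CNc2cc(-c3ccccn3)nc(NC)n2)cc1` gives 8 nM, the lowest; both differences to compound 1 lie beyond the usual scatter. Compound 3 carries an aromatic ring on the saturated chain carbon bound to the ring nitrogen, where compound 1 carries the tert-butyl.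

Compound 4 `CNc1nc(NCc2ccncc2)cc(-c2ccccn2)n1` is not yet measured in this assay. It differs from compound 1 by pyridin-4-yl in place of tert-butyl on a saturated chain carbon bound to a nitrogen on an aromatic ring. For the measured compounds named here, no directly comparable step among the measured compounds exists for this change. Given that compound 3, which also bears an aromatic ring at this position, gives 8 nM, compound 4 is expected to move toward a lower number, and the step from a 9.1-fold lower number from compound 1 to compound 4 (0.96 log units; beyond the scatter) is estimated to lie beyond the scatter. Compound 4 is therefore estimated at 40 nM, with a range of 10 nM to 160 nM.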

Compound 4, half-maximal effective concentration: 304 nM
Compound 4: middle estimate off by 7.6-fold (0.88 log units), on the low side, and the stated range ends below it.
By their numbers in this assay, from the lowest: compound 3; then compounds 4 and 1 (each within the scatter of the next); then compound 2.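

In this assay, the step with pyridin-4-yl in place of tert-butyl on a saturated chain carbon bound to a nitrogen on an aromatic ring is a 1.2-fold lower number from compound 1 to compound 4 (0.08 log units; within the scatter), so at this place the two groups cannot be told apart, although one is an aromatic ring and the other is not. An aromatic ring here is therefore not enough on its own to reach the number of compound 3 (8 nM), which bears a methyl amide on its ring. No measurement available explains why the two groups read alike.

Open, going by these compounds, is whether the low number of compound 3 follows its ring or its amide. A plain phenyl group at this place, or pyridin-4-yl bearing the same methyl amide, would separate the two.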